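The source may report more compounds than this note shows. Statements on the series, on what has been measured and on what is new or still open speak of the compounds shown alone.

Compounds measured so far:
Compound 1, `CCC(=O)N1CC2CC(C1)N2`, in an assay on SH-EP1 cells for agonist activity at Neuronal acetylcholine receptor; alpha4/beta2 (Homo sapiens), read by FLIPR and calcium flux (a higher number here means that more compound is needed for the effect, a lower number that less compound is needed), compound 1 gives 5900 nM.
Compound 2, `O=C([C@@H]1C[C@@H]1F)N1CC2CC(C1)N2`, in this assay compound 2 gives 370 nM.

Within the data shown here, compound 2 stands at the lowest of the two numbers; its nearest neighbour is compound 1, and the only step recorded, a 16-fold lower number from compound 1 to compound 2 (1.20 log units; beyond the scatter), lies beyond the scatter and concerns the replacement of the ethyl on the carbonyl carbon by a 2-fluorocyclopropyl group. Compound 3, `O=C([C@H]1C[C@@H]1F)N1CC2CC(C1)N2`, is not yet measured. It differs from compound 2 in this way: the two compounds have the same atoms and bonds; at least one stereo element is drawn with a configuration in one of them and without one in the other: 1 of 4 stereo elements differ; a stereocentre at a saturated ring carbon is drawn S in compound 2 and R in compound 3. The atoms and bonds are identical, and only the configuration at one saturated ring carbon is inverted.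

Among the measured compounds shown here, no measured step bears on a change of configuration alone; the step from compound 1 to compound 2 shows that the fluorocyclopropyl group as a whole matters, but it says nothing about which arrangement of its centres carries the effect. The expectation for compound 3 therefore rests on no directional evidence, and the expected step of a 1.9-fold higher number from compound 2 to compound 3 (0.28 log units; within the scatter) is set close to none, with a wide spread on both sides. Compound 3 is estimated at 700 nM, within a range from 150 nM to 3500 nM.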

Compound 3, half-maximal effective concentration: 2800 nM
Compound 3: the middle estimate sits 4.0-fold (0.60 log units) below what was measured; low and high end bracket the measured number.
By their numbers in this assay, from the lowest: compound 2; then compound 3; then compound 1.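

In this assay, the configuration at a single saturated ring carbon of the 2-fluorocyclopropyl group is enough on its own to shift the number, with no atom or bond changed: the result is a 7.6-fold higher number from compound 2 to compound 3 (0.88 log units; beyond the scatter). The advantage of this group over ethyl therefore depends on how its centres are arranged, since the inverted form retains only a 2.1-fold lower number from compound 1 to compound 3 (0.32 log units; beyond the scatter), compared with a 16-fold lower number from compound 1 to compound 2 (1.20 log units; beyond the scatter) for the other arrangement. The whole of the difference between compound 2 and compound 3 lies at one place, recorded as follows: the fact that one of compounds 2 and 3 is drawn with a defined configuration and the other without, at the place where they differ.

The compounds shown leave open how the remaining arrangements of the 2-fluorocyclopropyl centres would compare, so the effect of inverting the other ring carbon is not known. Going by these compounds, it also remains open how much of the gain over ethyl depends on the fluorine, as a plain cyclopropyl or a 2-methylcyclopropyl on the same carbonyl carbon would be needed to separate the contribution of the ring from that of its substituent.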